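The compounds below may be only part of what the source reports. "The series", "measured", "known", "first", "only" and "open" are said of these compounds alone.

Compound 1 `O=C(O)[C@@H]1CCCN1C(=O)CN(c1nc(Cl)nc2[nH]cnc12)C1CC1` was tested in a functional assay on the whole organism (Tail, strain ICR) with Mus musculus as the target, in the tail flick test, with a stated time of 30 min, at a dose of 25 umol/kg by the oral route (a lower number here means a weaker effect, a higher number a stronger effect of the compound at the dose given), where compound 1 gives 31.5%. Compound 3 `O=C(OCc1ccccc1)[C@@H]1CCCN1C(=O)CN(c1nc(Cl)nc2[nH]cnc12)C1CC1` gives 33.2% and compound 2 `CC(C)[C@H](NC(=O)CN(c1nc(Cl)nc2[nH]cnc12)C1CC1)C(=O)OCc1ccccc1` gives 33.4%, so compound 1 sits at one end of three numbers, none of which is separated from it beyond the scatter. Within the data shown here, the one step measured so far, a number 1.7 percentage points higher from compound 1 to compound 3 (within the scatter), lay within the scatter. Compound 4 `C[C@@H](O)[C@H](NC(=O)CN(c1nc(Cl)nc2[nH]cnc12)C1CC1)C(=O)O` differs from compound 1 at another place: (1-carboxy-2-hydroxypropyl)amino in place of 2-carboxypyrrolidin-1-yl on a carbonyl carbon. Among the measured compounds shown here, no measured step touches that side of the molecule, and the single known change elsewhere was flat, so compound 4 is expected to show a number 0.5 percentage points higher from compound 1 to compound 4 (within the scatter), nothing beyond the scatter. Compound 4 is therefore estimated at 32%, with a range from 22% to 42%.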

Compound 4, a percentage reported as activity, at one dose (the size of the read-out at that dose, not a potency): 18.6%
Compound 4: the middle estimate sits 13.4 percentage points above what was measured; the whole stated range lies above it.
By their numbers in this assay, from the lowest: compound 4; then compounds 1, 3 and 2 (each within the scatter of the next).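

In this assay, among these compounds, the substituent on the carbonyl carbon turns out to matter, unlike the one earlier step, which stayed flat: a number 12.9 percentage points lower from compound 1 to compound 4 (beyond the scatter). This step comes with (1-carboxy-2-hydroxypropyl)amino in place of 2-carboxypyrrolidin-1-yl, two groups with the same number of heavy atoms, so the heavy atom count alone does not set the read-out here. No available evidence accounts for the drop. The ring is lost and a hydroxyl and a second stereocentre are gained in one change, so the compounds shown leave open which of these carries the step. They also leave open how a simple amine or a longer alkyl chain on that carbonyl carbon would read.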